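Chloro to fluoro on the shared core: compound 3 to compound 4

The source may hold more compounds than are shown below. What is called first, only, known or untested is meant among the compounds shown, and "the series" means these compounds.

Measured in a functional assay on the whole organism with Mus musculus as the target, in the maximal electroshock model, with a stated time of 4 h; on this read-out higher numbers stand for an effect only at larger amounts of compound and lower numbers for an effect already at smaller amounts:

compound 1 `O=C(CCC(=O)c1ccccc1)Nc1nc2ccc(Br)cc2s1` gives 300 mg/kg
compound 2 `CC(=O)c1ccc2nc(NC(=O)CCC(=O)c3ccccc3)sc2c1` gives 100 mg/kg
compound 3 `O=C(Nc1nc2ccc(Cl)cc2s1)c1ccccc1C(=O)c1ccccc1` gives 100 mg/kg

Compound 3 stands level with compound 2 at the digits reported, and the two together hold the lowest numbers of the three. For the measured compounds named here, compound 1 is the outlier: compound 1 gives 300 mg/kg whereas compound 3 gives 100 mg/kg, a gap beyond the scatter, though no single-point step links these two.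

Compound 4 `O=C(Nc1nc2ccc(F)cc2s1)c1ccccc1C(=O)c1ccccc1` is the next member, differing from compound 3 only by fluoro in place of chloro on an aromatic carbon. Going by the values given here, the one measured step, a 3.0-fold lower number from compound 1 to compound 2 (0.48 log units; beyond the scatter), replaces bromo with acetyl, so it swaps a halogen for a carbonyl-bearing group and bears only loosely on a halogen-for-halogen change. Among the compounds with values here, no measured pair sets chloro against fluoro anywhere in the set. Within the data shown here, with compound 3 at 100 mg/kg and no step that speaks directly to the change, the expectation for compound 4 is no shift beyond the scatter, no change at the digits printed from compound 3 to compound 4 (within the scatter).

Compound 4 is therefore estimated at 100 mg/kg, with a range from 50 mg/kg to 300 mg/kg.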

Compound 4, minimum effective dose: 100 mg/kg
Beside the measured number, compound 4's estimate shows no gap at the digits printed; the range from low to high includes it.
By their numbers in this assay, from the lowest: compounds 2, 3 and 4 (each within the scatter of the next); then compound 1.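

In this assay the first pair setting one halogen against another gives no change at the digits printed from compound 3 to compound 4 (within the scatter), so on this aromatic carbon of the shared core, fluoro and chloro cannot be told apart on this read-out. For the compounds shown here, the only earlier step, a 3.0-fold lower number from compound 1 to compound 2 (0.48 log units; beyond the scatter), showed a change on an aromatic carbon moving the number beyond the scatter, but that step replaced bromo with acetyl on another core and left open whether a smaller exchange between halogens would do the same. The present pair adds a case in which a single-atom exchange on the aromatic carbon leaves the number within the scatter, and no available measurement bears on why the two halogens read alike.

From the compounds shown here alone, it remains open whether bromo or acetyl on the core of compound 3 would reproduce the gap seen in the earlier step, and whether fluoro and chloro would also read alike on the core of compound 1. Also open, going by these compounds, is how an amine, a carboxylic acid or a methoxy group on this aromatic carbon would read against the two halogens.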